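One Nitro Swap on a Compound at the Limit

This account rests on a few compounds, and the source may have more. Where it says the series, first, only, none or still open, it means among the compounds named here.

Measured in a functional assay on PLC-PRF-5 cells (Homo sapiens) for inhibition; on this read-out lower numbers stand for stronger inhibition and higher numbers for weaker inhibition:
Compound 1 `CNC(=O)c1cc(Oc2ccc(NS(=O)(=O)c3ccc(F)cc3)cc2)ccn1`: > 40000 nM
Compound 2 `O=C(Nc1cccc(Oc2ccnc3c([N+](=O)[O-])cccc23)c1)c1cc(C(F)(F)F)cc(C(F)(F)F)c1`: > 40000 nM

In this assay, compound 2 gives > 40000 nM, which is a limit and not a number. Compound 1 gives > 40000 nM, and this too is a limit. The whole picture so far is the limit of > 40000 nM in this assay, at which 2 of the 2 values shown sit. For the measured compounds named here, compound 2 therefore stands level with the only other measured compound, and neither offers a true number to build on.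

Compound 3 `CC(=O)Nc1cccc2c(Oc3cccc(NC(=O)c4cc(C(F)(F)F)cc(C(F)(F)F)c4)c3)ccnc12` keeps the core of compound 2 and changes a single group: acetamido in place of nitro on an aromatic carbon, (acetamido in place of nitro on an aromatic carbon). The group sits on a six-membered aromatic ring of carbon only, part of a fused or bridged system of two rings. Going by the values given here, no measured pair shows what this swap does in this assay. The expectation is therefore modest: little change beyond the scatter, with any movement towards stronger inhibition, and another limit is quite possible. The expected step of an at least 1.3-fold lower number from compound 2 to compound 3 (0.12 log units; that floor lies within the scatter) is small. For compound 3 the estimated value is 30000 nM, with an expected range from 10000 nM to 40000 nM.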

Compound 3, half-maximal inhibitory concentration: 10800 nM
The estimate for compound 3 lay 2.8-fold (0.44 log units) above the measured number; the measured number falls inside the stated range.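

In this assay, for the compounds shown here, putting acetamido in place of nitro gives an at least 3.7-fold lower number from compound 2 to compound 3 (0.56 log units; beyond the scatter) and is the only step here that can be read. It shows that this position, an aromatic carbon of a six-membered aromatic ring of carbon only, is not silent: with a change at this one place, compound 3 gives 10800 nM. As far as these compounds go, the full size of the step stays unknown, and only its floor can be stated, because the starting value of compound 2 is a limit and not a number: the limit of > 40000 nM in this assay, at which 2 of the 3 values shown sit.

With a single swap at this carbon, the compounds shown cannot tell whether the gain comes from the acetamido group as a whole or from one part of it, such as the carbonyl or the amide hydrogen. From the compounds shown here alone, a plain amine at the same carbon, or a longer chain on the same amide, would help to separate these possibilities, and it also remains open how much further the number can fall from compound 3.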